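Methyl in Place of Hydrogen on the Amide Chain

This account rests on a few compounds, and the source may have more. Where it says the series, first, only, none or still open, it means among the compounds named here.

Measured in a functional assay on NCI-H1975 cells (Homo sapiens) for antiproliferative activity, read by MTT assay, with a stated time of 72 h; on this read-out higher numbers stand for weaker inhibition and lower numbers for stronger inhibition:
Compound 1, `CC/C=C\C(=O)Nc1cc(Nc2ncc(C#N)c(-c3cn(C)c4ccccc34)n2)c(OC)cc1N(C)CCN(C)C`: 1150 nM
Compound 2, `CCC/C=C\C(=O)Nc1cc(Nc2ncc(C#N)c(-c3cn(C)c4ccccc34)n2)c(OC)cc1N(C)CCN(C)C`: 823 nM
Compound 3, `CC/C=C\C(=O)Nc1cc(Nc2nc(C)cc(-c3cn(C)c4ccccc34)n2)c(OC)cc1N(C)CCN(C)C`: 1990 nM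

Compound 2 differs from compound 1 by methyl in place of hydrogen on a saturated chain carbon, two bonds along the chain from a double-bonded chain carbon, and this gave a 1.4-fold lower number from compound 1 to compound 2 (0.15 log units; within the scatter). Compound 4, `COc1cc(N(C)CCN(C)C)c(NC(=O)/C=C\C(C)C)cc1Nc1nc(C)cc(-c2cn(C)c3ccccc23)n1`, is not yet measured; it differs from compound 3 by methyl in place of hydrogen on a saturated chain carbon bound to a double-bonded chain carbon and a saturated chain carbon. This is the same kind of change, not the same: in compound 2 the methyl sits two bonds along the chain from a double-bonded chain carbon, whereas in compound 4 it sits on a saturated chain carbon bound to a double-bonded chain carbon and a saturated chain carbon. The difference between the core of compound 3 and the core of compound 1 is not broken down here. Since the earlier step was a 1.4-fold lower number from compound 1 to compound 2 (0.15 log units; within the scatter), a step of similar size is expected, a 1.3-fold lower number from compound 3 to compound 4 (0.12 log units; within the scatter). Compound 4 is therefore estimated at 1500 nM, between 700 nM and 3500 nM.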

Compound 4, half-maximal inhibitory concentration: 1230 nM
Estimate against measurement, compound 4: 1.2-fold (0.09 log units) above; the range from low to high includes it.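

In this assay, methyl in place of hydrogen on the core of compound 3 gave a 1.6-fold lower number from compound 3 to compound 4 (0.21 log units; within the scatter). Set beside the earlier step, the change behaves alike on the two cores: the same change on two cores in this assay, a 1.4-fold lower number (0.15 log units; within the scatter) from compound 1 to compound 2 and a 1.6-fold lower number (0.21 log units; within the scatter) from compound 3 to compound 4, 1.2-fold (0.06 log units) apart, within the scatter of two such steps. This shows no difference in carrying the change from one core to the other, but it does not show that the methyl alters the number on either core, since each step lies within the scatter; nor is it one identical site, as the methyl sits two bonds along the chain from a double-bonded chain carbon in compound 2 but on a saturated chain carbon bound to a double-bonded chain carbon and a saturated chain carbon in compound 4.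

The compounds shown leave open whether a longer chain or an amine in place of the methyl would give a step beyond the scatter. They also leave open how the 3-methylbut-1-en-1-yl chain would fare on the core of compound 1.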